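Bromo in Place of Trifluoromethyl: Cytotoxicity Outlook

A few compounds are considered here, and "the series" means these few. Any claim that something is new, unique, unknown or untested is made for them only; others in the source may bear on it.

Compound 1 `C/C(=N\NC(=O)c1ccncc1)C(=O)Nc1ccc(C(F)(F)F)cc1` gives > 50000 nM in an ADME assay on HepG2 cells (Homo sapiens) for cytotoxicity, read by MTT assay (on this read-out lower numbers stand for stronger inhibition and higher numbers for weaker inhibition), which is a limit of the assay rather than a number.
Compound 2 `C/C(=N\NC(=O)c1ccncc1)C(=O)Nc1ccc(Cl)cc1` gives > 50000 nM in this assay, likewise a limit.

Among the measured compounds shown here, compound 1 therefore stands at the assay limit, and the one other value shown sits there too (the limit of > 50000 nM in this assay, at which 2 of the 2 values shown sit). Compound 3 `C/C(=N\NC(=O)c1ccncc1)C(=O)Nc1ccc(Br)cc1` differs from compound 1 by bromo in place of trifluoromethyl on an aromatic carbon. For the measured compounds named here, the only measured step that bears on this change is a step that the two limits leave unreadable from compound 1 to compound 2, and it cannot be read since both values are limits (the limit of > 50000 nM in this assay, at which 2 of the 2 values shown sit). No step beyond the scatter is therefore expected. Compound 3 is expected to give 70000 nM in this assay, within a range from 30000 nM to 200000 nM. The expected step is a step that the limit leaves unreadable from compound 1 to compound 3.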

Compound 3, half-maximal inhibitory concentration: > 50000 nM
Compound 3 was reported as a limit (the forecaster's own chance of this, stated with the estimate: 80%); the middle value lies beyond the limit too.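

No step can be read among compound 1, compound 2 and compound 3, because each result is a limit rather than a number: the limit of > 50000 nM in this assay, at which 3 of the 3 values shown sit.

The compounds shown leave open whether trifluoromethyl, chloro and bromo differ at all in this assay.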